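A few compounds are considered here, and "the series" means these few. Any claim that something is new, unique, unknown or untested is made for them only; others in the source may bear on it.

Compound 1 `CN(Cc1nc2ccccc2n1CCN)C1CCCc2cccnc21`: > 20000 nM
Compound 2 `CN(C)CCCn1c(CN(C)C2CCCc3cccnc32)nc2ccccc21`: 16800 nM

In an ADME assay on HOS cells (Homo sapiens) for cytotoxicity (on this read-out lower numbers stand for higher toxicity in this test and higher numbers for lower toxicity in this test), compound 1 is reported only as a limit, > 20000 nM. Within the data shown here, compound 2, at 16800 nM, holds the only actual number so far, and the other result is the limit of > 20000 nM in this assay, at which 1 of the 2 values shown sits. Compound 3 `CN(Cc1nc2ccccc2n1CCCNC(=N)N)C1CCCc2cccnc21` differs from compound 2 by one change: a group of 4 heavy atoms (1 carbon, 3 nitrogen; no ring) in place of a group of 3 heavy atoms (2 carbon, 1 nitrogen; no ring), on a saturated chain carbon, three bonds along the chain from an aromatic nitrogen. A single measured step offers guidance, also on a saturated chain carbon: an at least 1.1-fold lower number from compound 1 to compound 2 (0.07 log units; that floor lies within the scatter). Going by that small step, no shift beyond the scatter is expected, in either direction. The expected change is a 1.0-fold higher number from compound 2 to compound 3 (0.01 log units; within the scatter). For compound 3 the estimated value is 17000 nM, with an expected range of 8000 nM to 20000 nM.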

Compound 3, half-maximal cytotoxic concentration: > 20000 nM
Compound 3 gave a limit, no number; the forecaster's own chance of this, stated with the estimate: 45%; at least 1.1-fold (0.07 log units) between middle value and limit.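

The change at this position, from dimethylamino to the new group of 4 heavy atoms, gives an at least 1.1-fold higher number from compound 2 to compound 3 (0.07 log units; that floor lies within the scatter). In this assay, this position therefore accepts a group with more hydrogen-bond donors without any sign of a lower number. Compound 3 joins compound 1 at a limit, not a number, and the step between these two compounds cannot be read: the limit of > 20000 nM in this assay, at which 2 of the 3 values shown sit.

From the compounds shown here alone, how far the true values of compound 1 and compound 3 lie from that limit stays open. So does whether a carboxylic acid or a longer chain at this position would bring the number down.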